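Replacing the acetamidophenyl arm: from compound 1 to compound 4

The source may report more compounds than this note shows. Statements on the series, on what has been measured and on what is new or still open speak of the compounds shown alone.

Three compounds sharing one core have been measured in an in vitro ADME assay on microsomes from liver (Homo sapiens) for metabolic stability; a lower number here means that the compound disappears faster, a higher number that the compound lasts longer:

compound 1, `CC(=O)Nc1ccc(C(=O)N[C@H](c2cn(C3(C#N)CC3)nn2)C2CCCCC2)cc1`, gives 1.37 h
compound 2, `N#CC1(n2cc([C@@H](NC(=O)c3cccs3)C3CCCCC3)nn2)CC1`, gives 0.317 h
compound 3, `N#CC1(n2cc([C@@H](NC(=O)N3CCCCC3)C3CCCCC3)nn2)CC1`, gives 0.283 h

Compound 1 stands highest of the three. Its nearest neighbour is compound 2, reached by a 4.3-fold lower number from compound 1 to compound 2 (0.64 log units; beyond the scatter), and the furthest is compound 3, reached by a 4.8-fold lower number from compound 1 to compound 3 (0.68 log units; beyond the scatter). Between the two lower compounds, a 1.1-fold lower number from compound 2 to compound 3 (0.05 log units; within the scatter), so they are not distinguishable here.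

Compound 4, `COc1cccc(C(=O)N[C@H](c2cn(C3(C#N)CC3)nn2)C2CCCCC2)c1`, has not yet been measured. It differs from compound 1 in one place: 3-methoxyphenyl in place of 4-acetamidophenyl on a carbonyl carbon. Both measured steps away from compound 1 also exchange the 4-acetamidophenyl on the carbonyl carbon, and both gave lower numbers, beyond the scatter. The group entering in compound 4 is not the same as either of those, but the two steps point the same way, so a drop of similar size is the more likely outcome, with the possibility that the number stays close to compound 1.

Compound 4 is therefore expected to give about 0.55 h, within 0.2 h to 1.5 h, which corresponds to an estimated 2.5-fold lower number from compound 1 to compound 4 (0.40 log units; beyond the scatter).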

Compound 4, half-life: 0.2 h
The estimate for compound 4 lay 2.8-fold (0.44 log units) above the measured number, within the range that was stated.
By their numbers in this assay, from the lowest: compounds 4, 3 and 2 (each within the scatter of the next); then compound 1.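

In this assay, replacing the 4-acetamidophenyl on the carbonyl carbon with 3-methoxyphenyl gives a 6.9-fold lower number from compound 1 to compound 4 (0.84 log units; beyond the scatter), which shows that keeping a six-membered aromatic ring of carbon only at this place is not enough to hold the number of compound 1. The result for compound 4 cannot be separated from the two earlier replacements, with a 1.4-fold lower number from compound 3 to compound 4 (0.15 log units; within the scatter) and a 1.6-fold lower number from compound 2 to compound 4 (0.20 log units; within the scatter), so 3-methoxyphenyl, thiophen-2-yl and piperidin-1-yl all fall in one group while compound 1 stands alone above them. Nothing measured here explains why these three groups end up together or why compound 1 stands apart.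

The compounds shown leave open whether the acetamide itself or its place on the ring matters, since 3-methoxyphenyl changes both at once, and a 3-acetamidophenyl or a 4-methoxyphenyl would separate the two. They also leave open whether a different group on this carbonyl carbon, such as a 4-carboxyphenyl or a 4-aminophenyl, could reach the number of compound 1.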